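The source may report more compounds than this note shows. Statements on the series, on what has been measured and on what is new or still open speak of the compounds shown alone.

Measured compounds:
compound 1, `O=C(Nc1cccc(-n2cc(-c3ccncc3)c(-c3cc(O)cc(Cl)c3)n2)c1)Nc1ccc(Cl)c(Cl)c1`, in a functional assay on HCT-116 cells (Homo sapiens) for inhibition, read by sulforhodamine B assay, with a stated time of 48 h, tested at 0.1 uM (on this read-out higher numbers stand for a weaker effect at the one concentration tested and lower numbers for a stronger effect), compound 1 gives 102%
compound 2, `COc1cc(Cl)cc(-c2nn(-c3cccc(NC(=O)Nc4cc(C(F)(F)F)cc(C(F)(F)F)c4)c3)cc2-c2ccncc2)c1`, in this assay compound 2 gives 97%

Among the two numbers measured in this assay, the number of compound 1 is the higher one, but its nearest neighbour, compound 2, lies lower by a gap that falls within the scatter of repeated measurements. Both measured compounds therefore leave the cell growth essentially untouched at the single concentration tested, and neither can be called the weaker or the stronger of the pair.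

Compound 3, `COc1cc(Cl)cc(-c2nn(-c3cccc(NC(=O)Nc4ccc(Cl)c(Cl)c4)c3)cc2-c2ccncc2)c1`, has not yet been measured in this assay. It is derived from compound 1 by a single small change: methyl in place of hydrogen on an oxygen on an aromatic ring. Going by the values given here, since both compound 1 and compound 2 sit at the top of the scale in this assay, there is no measured step from which a sizeable shift could be foreseen, and the swap of a hydrogen for a methyl on an oxygen is expected to produce no step beyond the scatter. The step from compound 1 to compound 3 in this assay is estimated as a number 4 percentage points lower from compound 1 to compound 3 (within the scatter). Compound 3 is expected to give 98%, within a range from 85% to 110%.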

Compound 3, a percentage reported as activity, at one concentration (the size of the read-out at that concentration, not a potency): 100%
The estimate for compound 3 lay 2 percentage points below the measured number; measured number inside the range.
By their numbers in this assay, from the lowest: compounds 2, 3 and 1 (each within the scatter of the next).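

In this assay, replacing hydroxy with methoxy on this oxygen on an aromatic ring gives a step of a number 2 percentage points lower from compound 1 to compound 3 (within the scatter), so at this one concentration the hydrogen and the methyl cannot be told apart. Going by these compounds alone, this is the first direct comparison at this position, and it shows that adding a methyl here does not bring out any measurable effect on cell growth, although the read-out for both compounds stays at the top of the scale, where a loss of effect would not be visible. Nothing available bears on why the step is so small.

From the compounds shown here alone, it remains open whether a larger group on this oxygen, such as a longer chain ending in an amine or a carboxylic acid, would move the read-out away from the top of the scale. Going by these compounds, it also remains open whether compound 1 and compound 3 would still be indistinguishable at a higher concentration, where a difference between hydroxy and methoxy might appear.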